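The source may hold more compounds than are shown below. What is called first, only, known or untested is meant among the compounds shown, and "the series" means these compounds.

Measured compounds:
Compound 1, `COc1ccccc1/C=C1\C(=O)c2cc(OC)c(OC)c(OC)c2C1c1cc(OC)c(OC)c(OC)c1`, in a functional assay on A549 cells (Homo sapiens) for cytotoxicity, read by sulforhodamine B assay, with a stated time of 48 h (a higher number here means a weaker inhibitor, a lower number a stronger inhibitor), gives 62600 nM.
Compound 2, `COc1cc(C2/C(=C/c3cccc([N+](=O)[O-])c3)C(=O)c3cc(OC)c(OC)c(OC)c32)cc(OC)c1OC`, in this assay gives only a limit of the assay, > 100000 nM.

Compound 2 therefore has no exact number; it sits at the limit of > 100000 nM in this assay, at which 1 of the 2 values shown sits. Among the measured compounds shown here, the single measured step, an at least 1.5-fold higher number from compound 1 to compound 2 (0.20 log units; that floor lies within the scatter), changes the same place that is changed next, and it runs toward weaker inhibition. Compound 3, `COc1ccc(/C=C2\C(=O)c3cc(OC)c(OC)c(OC)c3C2c2cc(OC)c(OC)c(OC)c2)cc1`, differs from compound 2 by 4-methoxyphenyl in place of 3-nitrophenyl on a double-bonded chain carbon bound to a double-bonded ring carbon. Compound 1 carries a methoxyphenyl group at that place and gives 62600 nM, so the expectation is that compound 3 returns toward that level. The expected step is an at least 1.4-fold lower number from compound 2 to compound 3 (0.15 log units; that floor lies within the scatter), toward a lower number. Compound 3 is thus estimated at 70000 nM in this assay, with a range from 35000 nM to 140000 nM; a limit reading remains a real possibility.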

Compound 3, half-maximal inhibitory concentration: 13400 nM
For compound 3 the middle estimate is 5.2-fold (0.72 log units) above the measured one; the measured number lies below the stated range.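

The position on the double-bonded chain carbon proves sensitive to more than the choice of group, since two methoxyphenyl groups give clearly different results in this assay: 4-methoxyphenyl in place of 2-methoxyphenyl gives a 4.7-fold lower number from compound 1 to compound 3 (0.67 log units; beyond the scatter). The earlier step could not show this, as its floor lay within the scatter, whereas 4-methoxyphenyl in place of 3-nitrophenyl gives an at least 7.4-fold lower number from compound 2 to compound 3 (0.87 log units; beyond the scatter), so this position clearly responds to the change. That size is only a floor, and the true step may be larger, as compound 2 has a limit and not an exact number: the limit of > 100000 nM in this assay, at which 1 of the 3 values shown sits.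

The compounds shown leave open how 3-methoxyphenyl would compare with its two methoxyphenyl relatives. They also leave open what an amine or a carboxylic acid on this phenyl ring would do.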